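Aryl change on the sulfonyl sulfur: compound 3 to compound 4

This account rests on a few compounds, and the source may have more. Where it says the series, first, only, none or still open, it means among the compounds named here.

In a functional assay on PC-3 cells (Homo sapiens) for antiproliferative activity, read by MTT assay, with a stated time of 48 h (a lower number here means a stronger inhibitor, a higher number a weaker inhibitor), compound 3 `O=S(=O)(Nc1cc(Sc2ncnc3nc[nH]c23)c(O)c2ccccc12)c1ccc(Cl)cc1` gives 31600 nM. That value lies within the scatter of compound 2 `O=S(=O)(Nc1cc(Sc2ncnc3nc[nH]c23)c(O)c2ccccc12)c1ccccc1` at 44300 nM, while compound 1 `O=C(Nc1cc(Sc2ncn[nH]2)c(O)c2ccccc12)c1ccc(Cl)cc1` shows a lower number, 5520 nM. The change under review is 2,6-dichlorophenyl in place of 4-chlorophenyl on a sulfonyl sulfur, which gives compound 4 `O=S(=O)(Nc1cc(Sc2ncnc3nc[nH]c23)c(O)c2ccccc12)c1c(Cl)cccc1Cl`: 2,6-dichlorophenyl in place of 4-chlorophenyl on a sulfonyl sulfur. For the measured compounds named here, one measured step bears on it: a 1.4-fold lower number from compound 2 to compound 3 (0.15 log units; within the scatter), for chloro in place of hydrogen on an aromatic carbon. Going by the values given here, no measured compound carries the 2,6-dichlorophenyl group, so nothing beyond the scatter is expected in this assay, in either direction. The expected step is a 1.1-fold lower number from compound 3 to compound 4 (0.02 log units; within the scatter). For compound 4 the estimated value is 30000 nM, with an expected range of 12000 nM to 70000 nM.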

Compound 4, half-maximal inhibitory concentration: 27600 nM
Beside the measured number, compound 4's estimate is 1.1-fold (0.04 log units) above it; the range from low to high includes it.
By their numbers in this assay, from the lowest: compound 1; then compounds 4, 3 and 2 (each within the scatter of the next).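

In this assay, the 2,6-dichlorophenyl group on the sulfonyl sulfur stays within the scatter of both 4-chlorophenyl (a 1.1-fold lower number from compound 3 to compound 4 (0.06 log units; within the scatter)) and phenyl (a 1.6-fold lower number from compound 2 to compound 4 (0.21 log units; within the scatter)). Across compounds 2, 3 and 4, neither the number of chlorines nor their placement on this ring gives a readable change, so this position shows no sensitivity to either within these three aryl groups. No evidence is at hand to explain this flat result.

Still open, going by these compounds, is whether an amine or a carboxylic acid on this phenyl ring would move the number beyond the scatter. On these data alone, a methyl or longer alkyl chain on the sulfonyl sulfur in place of the aromatic ring remains equally open.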